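A few compounds are considered here, and "the series" means these few. Any claim that something is new, unique, unknown or untested is made for them only; others in the source may bear on it.

Compound 3 `C[C@@H]1CN(C(=O)OC(C)(C)C)CCN1c1ncc(OCc2ccc(S(=O)(=O)N(C)C)cc2)cn1` sits in the middle of three compounds examined in a functional assay on isolated protein with Glucose-dependent insulinotropic receptor (Mus musculus) as the target, read by HTRF and cAMP accumulation, with a stated time of 45 min; on this read-out lower numbers stand for smaller maximal responses and higher numbers for larger maximal responses: it gives 39%. Its nearest neighbour is compound 2 `C[C@@H]1CN(C(=O)OC(C)(C)C)CCN1c1ncc(OCC2CCN(S(C)(=O)=O)CC2)cn1`, which in this assay reaches 67%, a gap beyond the scatter. Furthest off is compound 1 `CC(C)(C)OC(=O)N1C[C@@H]2CC[C@H]1CN2c1ncc(OCc2ccc(S(C)(=O)=O)cc2)cn1`, which in this assay shows 0%, also beyond the scatter. Compound 4 `C[C@@H]1CN(C(=O)OC(C)(C)C)CCN1c1ncc(OCc2ccc(C#N)cc2)cn1` is not yet measured and differs from compound 3 in one place: cyano in place of dimethylsulfamoyl on an aromatic carbon. Within the data shown here, no measured pair shows this change, so its effect rests on expectation alone. For compound 4 the step from compound 3 is expected to be small in this assay, not clearly beyond the scatter in either direction, as a number 1 percentage points higher from compound 3 to compound 4 (within the scatter). Compound 4 is therefore estimated at 40%, within a range from 10% to 70%.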

Compound 4, intrinsic activity: the largest response reached, in percent of the reference agonist's: 88%
Beside the measured number, compound 4's estimate is 48 percentage points below it, outside the stated range (above it).
By their numbers in this assay, from the lowest: compound 1; then compound 3; then compound 2; then compound 4.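

On an aromatic carbon para to a large group, the choice of substituent clearly matters in this assay: cyano in place of dimethylsulfamoyl gives a number 49 percentage points higher from compound 3 to compound 4 (beyond the scatter). With 4-cyanophenyl in place of 1-(methylsulfonyl)piperidin-4-yl, the read-out also shows a number 21 percentage points higher from compound 2 to compound 4 (beyond the scatter), so the sulfonyl-bearing groups of these two pairs fall short of the cyano-bearing one. Nothing at hand accounts for either step. Open, going by these compounds, is how an amine, a carboxylic acid or trifluoromethyl would read on this aromatic carbon. Also open, on these data alone, is whether cyano would change the response on the core of compound 1.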